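Benzothiazole amide series: expectation for compound 4

The source may hold more compounds than are shown below. What is called first, only, known or untested is meant among the compounds shown, and "the series" means these compounds.

Measured so far in a functional assay on A549 cells (Homo sapiens) for cytotoxicity, read by MTT assay, with a stated time of 48 h; a higher number here means a weaker inhibitor, a lower number a stronger inhibitor:
compound 1 `COc1ccc(-c2cc(C(=O)Nc3nc4ccc(Cl)cc4s3)nc3cc(-c4ccccc4)nn23)cc1`: 3090 nM
compound 2 `COc1ccc(-c2cc(C(=O)Nc3nc4ccccc4s3)nc3cc(-c4ccccc4)nn23)cc1`: 1540 nM
compound 3 `COc1ccc(-c2cc(C(=O)Nc3nc4ccccc4s3)nc3cc(-c4ccccc4)nn23)cc1OC`: 5490 nM

Compound 2 gives the lowest number of the three; compound 1 differs from it only within the scatter (a 2.0-fold lower number from compound 1 to compound 2 (0.30 log units; within the scatter)), whereas compound 3 sits clearly higher (a 3.6-fold higher number from compound 2 to compound 3 (0.55 log units; beyond the scatter)). Compound 4 `COc1ccc(-c2cc(C(=O)Nc3nc4cc(C)c(C)cc4s3)nc3cc(-c4ccccc4)nn23)cc1` is not yet measured. It differs from compound 2 by 5,6-dimethyl-1,3-benzothiazol-2-yl in place of 1,3-benzothiazol-2-yl on an amide-type nitrogen. Within the data shown here, only one measured step concerns a change on the same ring, a 2.0-fold lower number from compound 1 to compound 2 (0.30 log units; within the scatter), and it stayed within the scatter; the step to compound 3 concerns a different part of the molecule and does not bear on it. A step no larger than the scatter, if anything toward a slightly higher number, is therefore expected: a 1.6-fold higher number from compound 2 to compound 4 (0.21 log units; within the scatter). The estimate for compound 4 in this assay is 2500 nM, with a range from 900 nM to 7000 nM.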

Compound 4, half-maximal inhibitory concentration: 13200 nM
For compound 4 the middle estimate is 5.3-fold (0.72 log units) below the measured one; measured number outside the range, above it.
By their numbers in this assay, from the lowest: compounds 2, 1 and 3 (each within the scatter of the next, the first and the last beyond it); then compound 4.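

In this assay the ring on the amide-type nitrogen proves sensitive to substitution: 5,6-dimethyl-1,3-benzothiazol-2-yl in place of 1,3-benzothiazol-2-yl gives an 8.6-fold higher number from compound 2 to compound 4 (0.93 log units; beyond the scatter) while 6-chloro-1,3-benzothiazol-2-yl had stayed within the scatter of the unsubstituted ring. The change from the chloro group to the two methyl groups also registers, with a 4.3-fold higher number from compound 1 to compound 4 (0.63 log units; beyond the scatter) as the step beyond the scatter. No available evidence accounts for this shift.

Going by these compounds, whether a single methyl group would produce the same shift remains open. The effect of an amine or a carboxylic acid on this ring is also unresolved.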